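The compounds below may be only part of what the source reports. "The series", "measured", "known", "first", "only" and "open" are said of these compounds alone.

Working notes on the aryl pyrrolidine carboxylic acid series.

Three members have been measured in an assay on cells for inhibition of Palmitoleoyl-protein carboxylesterase NOTUM variant C330S (Homo sapiens), read by fluorescence, with a stated time of 40 min; on this read-out higher numbers stand for weaker inhibition and lower numbers for stronger inhibition. Compound 1 `O=C(O)C1CCN(c2cccc(Cl)c2Cl)C1` gives 8000 nM, compound 2 `O=C(O)C1CCN(c2ccc(Cl)cc2Cl)C1` gives 10000 nM, and compound 3 `O=C(O)C1CCN(c2ccc(Cl)c(Cl)c2)C1` gives 1200 nM. Compound 3 thus carries the lowest number of the three; the gap to compound 1 and the gap to compound 2 are both beyond the usual scatter, so compound 3 stands as the strongest inhibitor measured so far.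

Compound 4 `O=C(O)C1CCN(c2ccc(Cl)c(Cl)c2Cl)C1` has not yet been measured. It differs from compound 3 by chloro in place of hydrogen on an aromatic carbon. Among the compounds with values here, no measured pair shows this exact change, so its size is open. Compounds 1 and 2, which carry chloro at other positions of the same ring, both sit well above compound 3, so a modest weakening is expected rather than a gain: the step from compound 3 to compound 4 is estimated as a 2.1-fold higher number from compound 3 to compound 4 (0.32 log units; beyond the scatter), close to the edge of scatter. Compound 4 is accordingly expected to give about 2500 nM, with a plausible range from 800 nM to 8000 nM.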

Compound 4, half-maximal inhibitory concentration: 600 nM
Estimate against measurement, compound 4: 4.2-fold (0.62 log units) above, and the stated range ends above it.
By their numbers in this assay, from the lowest: compounds 4 and 3 (each within the scatter of the next); then compounds 1 and 2 (each within the scatter of the next).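

Chloro in place of hydrogen on this aromatic carbon, ortho to the group of 8 heavy atoms, gives a 2.0-fold lower number from compound 3 to compound 4 (0.30 log units; within the scatter), so a chloro here does not by itself go with a high number. The same change on other carbons of the ring gives much larger steps, a 17-fold lower number from compound 2 to compound 4 (1.22 log units; beyond the scatter) and a 13-fold lower number from compound 1 to compound 4 (1.12 log units; beyond the scatter), so its effect depends on where it is made among these compounds.

No measurement available here accounts for these steps. Still open, from the compounds shown here alone, is how a fluoro, a methoxy or an amine would read on this carbon.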